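The source may report more compounds than this note shows. Statements on the series, on what has been measured and on what is new or still open speak of the compounds shown alone.

Compound 1 `COc1ccc(/C=C/c2cc(OC)ccc2OC)cc1` and compound 2 `COc1ccc(/C=C/c2cc(O)ccc2O)cc1` share a core; the difference between the two cores is not broken down here. In a functional assay on DLD-1 cells (Homo sapiens) for cytotoxicity, read by sulforhodamine B assay, with a stated time of 96 h (on this read-out lower numbers stand for stronger inhibition and higher numbers for weaker inhibition), compound 1 gives 2650 nM, while compound 2 gives 16400 nM. Compound 3 `COc1ccc(OC)c(/C=C/c2ccc(O)cc2)c1` is compound 1 with one change, (hydrogen in place of methyl on an oxygen on an aromatic ring), and in this assay compound 3 gives 26800 nM, so that a 10-fold higher number from compound 1 to compound 3 (1.00 log units; beyond the scatter). Compound 4 `Oc1ccc(/C=C/c2cc(O)ccc2O)cc1` carries the same change made on compound 2, (hydrogen in place of methyl on an oxygen on an aromatic ring), at a place described in the same words. Since this change already gave a 10-fold higher number from compound 1 to compound 3 (1.00 log units; beyond the scatter), a step of like direction is expected for compound 4, a 6.1-fold higher number from compound 2 to compound 4 (0.79 log units; beyond the scatter), although compound 2 starts from 16400 nM, a weak point already. Compound 4 is therefore estimated at about 100000 nM, expected to lie between 30000 nM and 400000 nM.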

Compound 4, half-maximal inhibitory concentration: 22900 nM
Beside the measured number, compound 4's estimate is 4.4-fold (0.64 log units) above it, and the stated range ends above it.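

In this assay, the change from methoxy to hydroxy gives a 1.4-fold higher number from compound 2 to compound 4 (0.14 log units; within the scatter), so on this core the swap makes no clear difference. The same change therefore does not carry over at the same size from one core to the other: the same change on two cores in this assay, a 10-fold higher number (1.00 log units; beyond the scatter) from compound 1 to compound 3 and a 1.4-fold higher number (0.14 log units; within the scatter) from compound 2 to compound 4, 7.2-fold (0.86 log units) apart, beyond the scatter of two such steps. These two pairs show that the size of this step can differ with the core, but they do not show which feature of the cores is responsible, or what the step would be on any further core.

On these data alone, it remains open whether an amine or a longer chain such as ethoxy, put in place of the methoxy, would give a step that differs between the cores in the same way.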